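A few compounds are considered here, and "the series" means these few. Any claim that something is new, unique, unknown or untested is made for them only; others in the source may bear on it.

Measured so far:
- compound 1, `O=C(N/N=C/c1cccc(Br)c1)c1cnccn1`: 93%
- compound 2, `O=C(N/N=C/c1cccc(O)c1)c1cnccn1`: 88%

Both numbers come from an ADME assay on J774 cells (Mus musculus) for cytotoxicity, read by MTT assay, with a stated time of 48 h, tested at 150 ug/mL; on this read-out lower numbers stand for a stronger effect and higher numbers for a weaker effect at the one concentration tested. Compound 1 gives 93% and compound 2 gives 88%; the step between them, a number 5 percentage points lower from compound 1 to compound 2 (within the scatter), is within the scatter, so on this read-out the two compounds cannot be told apart. Compound 2 therefore stands together with compound 1 at a weak effect, and nothing in the pair separates them.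

The next compound, compound 3, `N#Cc1cccc(/C=N/NC(=O)c2cnccn2)c1`, differs from compound 2 in one place: cyano in place of hydroxy on an aromatic carbon. For the measured compounds named here, the only measured step that bears on a change at this aromatic carbon is the one from compound 1 to compound 2, which was within the scatter, and it replaced a different group. There is thus no measured step beyond the scatter to carry over, and none is expected from the new change either; the expectation is a number close to that of compound 2.

Compound 3 is expected at 90%, with a range from 78% to 100%. The expected step is a number 2 percentage points higher from compound 2 to compound 3 (within the scatter), that is, none beyond the scatter.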

Compound 3, a percentage reported as activity, at one concentration (the size of the read-out at that concentration, not a potency): 100%
Compound 3: the middle estimate sits 10 percentage points below what was measured; the range from low to high includes it.
By their numbers in this assay, from the lowest: compounds 2, 1 and 3 (each within the scatter of the next, the first and the last beyond it).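

In this assay, the aromatic carbon meta to a large group now gives its first step beyond the scatter: the change of hydroxy to cyano yields a number 12 percentage points higher from compound 2 to compound 3 (beyond the scatter) and is modest in size, so the number here is not wholly indifferent to the group carried. The same cyano set against bromo gives a number 7 percentage points higher from compound 1 to compound 3 (within the scatter), so compound 1 and compound 3 cannot be told apart, and compound 1 also stands within the scatter of compound 2; the only separation in these three compounds is between the hydroxy and cyano compounds, and it does not amount to an ordering of all three groups. No measurement at hand offers an explanation for that one separation.

Open, going by these compounds, is whether the hydroxy is distinctive at this carbon or the gap is simply the widest spread among groups that all leave the number high. An amine, a carboxylic acid or a methoxy group on the same carbon would show whether any group here moves the number further down than the hydroxy does.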